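Halogen swap on the aryl ether of compound 2

The source may hold more compounds than are shown below. What is called first, only, known or untested is meant among the compounds shown, and "the series" means these compounds.

Among the compounds with values here, compound 2 `Cn1c(=O)c2c(nc(COc3cccc(Br)c3)n2C)n(C)c1=O` gives 148 nM in an in vitro assay on cells for inhibition of Amine oxidase [flavin-containing] B (Homo sapiens), read by coupled enzyme assay, with a stated time of 20 min (on this read-out lower numbers stand for stronger inhibition and higher numbers for weaker inhibition), the lowest of the three numbers measured so far. Compound 3 `Cn1c(=O)c2c(nc(CCSc3ccc(Cl)cc3)n2C)n(C)c1=O` gives 7790 nM and compound 1 `Cn1c(=O)c2c(nc(CCSc3cccc(Br)c3)n2C)n(C)c1=O` gives 64100 nM in this assay. Compound 4 `Cn1c(=O)c2c(nc(COc3cccc(Cl)c3)n2C)n(C)c1=O` is not yet measured; the change from compound 2 is chloro in place of bromo on an aromatic carbon, meta to a large group. Within the data shown here, the only measured step touching a halogen is an 8.2-fold lower number from compound 1 to compound 3 (0.92 log units; beyond the scatter), which changes position and halogen together on a sulfur, so it bears only loosely on a pure chloro for bromo exchange. Such a swap is expected to give a small step in this assay, if any beyond the scatter, in either direction. Compound 4 is therefore estimated at 200 nM, range 80 nM to 500 nM. The expected step is a 1.4-fold higher number from compound 2 to compound 4 (0.13 log units; within the scatter).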

Compound 4, half-maximal inhibitory concentration: 334 nM
Estimate against measurement, compound 4: 1.7-fold (0.22 log units) below, within the range that was stated.
By their numbers in this assay, from the lowest: compound 2; then compound 4; then compound 3; then compound 1.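

In this assay chloro in place of bromo on an aromatic carbon, meta to a large group, gives a 2.3-fold higher number from compound 2 to compound 4 (0.35 log units; beyond the scatter) with nothing else changed. The halogen alone therefore moves the number, modestly, whereas the earlier halogen step changed position as well. Nothing measured here gives a reason for this step.

The compounds shown leave open how a fluoro or a methoxy group on the same aromatic carbon would read. They also leave open whether this exchange gives a similar step with the sulfur chain of compound 1.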